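Chain shortening in diaryl urea ACAT inhibitors

The source may hold more compounds than are shown below. What is called first, only, known or untested is meant among the compounds shown, and "the series" means these compounds.

Compound 1 `CCCCCCCCCCCCCCCCCCNC(=O)Nc1c(C)cccc1Cl` gives 1100 nM in an assay on microsomes from intestinal mucosa for inhibition of acyl-CoA:cholesterol acyltransferase (Oryctolagus cuniculus); a lower number here means a stronger inhibitor, a higher number a weaker inhibitor. Compound 2 `CCCCCCCCCCCCCCNC(=O)Nc1c(C)cccc1Cl` gives 70 nM in this assay; the change hydrogen in place of butyl on a saturated chain carbon, ten or more bonds along the chain from an amide-type nitrogen produced the step of a 16-fold lower number from compound 1 to compound 2 (1.20 log units; beyond the scatter). Compound 3 `CCCCCCCCCCNC(=O)Nc1c(C(C)C)cccc1C(C)C` gives 56 nM in this assay, within the scatter of compound 2; the difference between the cores of compound 1 and compound 3 is not broken down here. Compound 4 `CCCCCCNC(=O)Nc1c(C(C)C)cccc1C(C)C` is not yet measured. It carries the same kind of change as before, (hydrogen in place of butyl on a saturated chain carbon, six bonds along the chain from an amide-type nitrogen), but at a different place along the chain from the amide-type nitrogen, as the two counted differences show. Since the earlier step of a 16-fold lower number from compound 1 to compound 2 (1.20 log units; beyond the scatter) was measured on a much longer chain, the same gain is not expected; a moderate weakening is estimated instead, a 3.6-fold higher number from compound 3 to compound 4 (0.55 log units; beyond the scatter). Compound 4 is expected to give 200 nM in this assay, with a range from 40 nM to 1500 nM.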

Compound 4, half-maximal inhibitory concentration: 99 nM
Beside the measured number, compound 4's estimate is 2.0-fold (0.31 log units) above it; low and high end bracket the measured number.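

The change of butyl to hydrogen does not carry over from one core to the other as a fixed step in this assay: the same change on two cores in this assay, a 16-fold lower number (1.20 log units; beyond the scatter) from compound 1 to compound 2 and a 1.8-fold higher number (0.25 log units; within the scatter) from compound 3 to compound 4, 28-fold (1.44 log units) apart, beyond the scatter of two such steps
At the place six bonds along the chain from an amide-type nitrogen, the step of a 1.8-fold higher number from compound 3 to compound 4 (0.25 log units; within the scatter) gives no difference that can be told from repeat measurements. The two steps differ in both core and place along the chain, so the gap does not show which of these two differences sets the outcome.

Still open, from the compounds shown here alone, is how the same change behaves at one and the same chain place on both cores. Also open, going by these compounds, is how a chain ending in an amine or a carboxylic acid would read in this assay on either core.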